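The compounds below may be only part of what the source reports. "The series", "measured", "known", "first", "only" and "open" are said of these compounds alone.

Measured compounds:
compound 1 `COCC1=CS(=O)(=O)c2ccccc2C1=O` — 99.9%
compound 2 `COCCOCC1=CS(=O)(=O)c2ccccc2C1=O` — 98.2%
compound 3 `O=C(OCC1=CS(=O)(=O)c2ccccc2C1=O)c1ccccc1` — 0%

In a functional assay on the whole organism for inhibition, with Mus musculus as the target, at a dose of 10 mg/kg (on this read-out lower numbers stand for less inhibition and higher numbers for more inhibition at the one dose given (going by the name of the read-out)), compound 3 gives 0%, the lowest of the three numbers, beyond the scatter from both compound 2 and compound 1; compound 1 and compound 2 sit close together at the top of the range. Going by the values given here, the one step with a single change, a number 1.7 percentage points lower from compound 1 to compound 2 (within the scatter), lies within the scatter and concerns the ether chain, not the carbonyl carbon.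

Compound 4 `CCNC(=O)OCC1=CS(=O)(=O)c2ccccc2C1=O` differs from compound 3 by ethylamino in place of phenyl on a carbonyl carbon. Among the compounds with values here, no measured step touches a carbonyl carbon, so nothing bears directly on this change. Within the data shown here, what the numbers show is that the two ether compounds inhibit nearly fully and the one acyl compound, compound 3, not at all; compound 4 keeps an acyl group on that oxygen. The direction of a number 35 percentage points higher from compound 3 to compound 4 (beyond the scatter) in this assay is therefore expected to be upward only weakly, with wide uncertainty. Compound 4 is estimated at 35%, within 0% to 90%.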

Compound 4, a percentage reported as inhibition, in the whole organism at one dose (the size of the read-out at that dose, not a potency): 99.3%
Compound 4: the middle estimate sits 64.3 percentage points below what was measured; the measured number lies above the stated range.
By their numbers in this assay, from the lowest: compound 3; then compounds 2, 4 and 1 (each within the scatter of the next).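

In this assay, an acyl group on this oxygen does not by itself go with a loss of inhibition: ethylamino in place of phenyl on the carbonyl carbon gives a number 99.3 percentage points higher from compound 3 to compound 4 (beyond the scatter). Ethylcarbamoyl on the oxygen also stands level with the ether groups, with a number 1.1 percentage points higher from compound 2 to compound 4 (within the scatter) and a number 0.6 percentage points lower from compound 1 to compound 4 (within the scatter), so among these four compounds only compound 3 stands apart. No measurement at hand explains the gap between the phenyl and ethylamino compounds.

Going by these compounds, the swap changes both the ring and the nitrogen at once, so it remains open which of the two tracks with the result; a methyl or a phenylamino group on the same carbonyl carbon would separate them. On these data alone, with compound 1, compound 2 and compound 4 all at the top of the range at one dose, any difference in potency among them also remains open.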